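From Chloro to Bromo in a Small Amide Series

A few compounds are considered here, and "the series" means these few. Any claim that something is new, unique, unknown or untested is made for them only; others in the source may bear on it.

Compound 1 `O=C(Nc1cc(C(F)(F)F)cc(C(F)(F)F)c1)c1cc(Br)c(F)cc1O` gives 950 nM
Compound 2 `O=C(Nc1cc(C(F)(F)F)cc(C(F)(F)F)c1)c1ccc(Cl)cc1O` gives 850 nM

In a functional assay on NALM-6 cells (Homo sapiens) for cytotoxicity, read by luminescence and CellTiter-Glo, with a stated time of 3 days (a higher number here means a weaker inhibitor, a lower number a stronger inhibitor), compound 2 gives 850 nM and compound 1 gives 950 nM so the two values lie within the scatter of each other. Compound 3 `O=C(Nc1cc(C(F)(F)F)cc(C(F)(F)F)c1)c1cc(Br)ccc1O` has not yet been measured. It differs from compound 2 by 5-bromo-2-hydroxyphenyl in place of 4-chloro-2-hydroxyphenyl on a carbonyl carbon and so carries 5-bromo-2-hydroxyphenyl in place of 4-chloro-2-hydroxyphenyl on a carbonyl carbon. Compound 1 also carries a bromine and gives 950 nM in the same range as compound 2, so no large change is foreseen. The estimated 1.2-fold lower number from compound 2 to compound 3 (0.08 log units; within the scatter) is expected to stay within the scatter of this assay in either direction. Compound 3 is expected at 700 nM with an estimated range of 250 nM to 1800 nM in this assay.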

Compound 3, half-maximal inhibitory concentration: 590 nM
Beside the measured number, compound 3's estimate is 1.2-fold (0.07 log units) above it; the range from low to high includes it.
By their numbers in this assay, from the lowest: compounds 3, 2 and 1 (each within the scatter of the next).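

In this assay, 5-bromo-2-hydroxyphenyl in place of 4-chloro-2-hydroxyphenyl on a carbonyl carbon gives a 1.4-fold lower number from compound 2 to compound 3 (0.16 log units; within the scatter), so this exchange of halogen and its place does not move the number beyond the scatter. Hydrogen in place of fluoro on an aromatic carbon gives a 1.6-fold lower number from compound 1 to compound 3 (0.21 log units; within the scatter), which likewise stays within the scatter. Nothing available bears on the reason for these values.

The first step changes the halogen and its place together, and the compounds shown do not separate the two. On these data alone, an amine or a carboxylic acid in place of the halogen remains open.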